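Swapping a chlorinated ring for a saturated one

The compounds below may be only part of what the source reports. "The series", "measured", "known", "first", "only" and "open" are said of these compounds alone.

Three compounds share one core and were tested in a functional assay on A549 cells (Homo sapiens) for cytotoxicity, read by MTT assay, with a stated time of 72 h; a higher number here means a weaker inhibitor, a lower number a stronger inhibitor. Compound 1 `O=C(Nc1nnc(-c2cccc(O)c2O)s1)c1ccccc1` gives 12300 nM, and compound 2 `O=C(Nc1nnc(-c2cccc(O)c2O)s1)C1CCCCC1` gives 11000 nM. Compound 3 `O=C(Nc1nnc(-c2ccc(O)c(O)c2)s1)c1ccc(Cl)cc1` gives 14600 nM, the highest of the three numbers, though its gaps to the other two lie within the scatter. Compound 4 `O=C(Nc1nnc(-c2ccc(O)c(O)c2)s1)C1CCCCC1` differs from compound 3 by one change: cyclohexyl in place of 4-chlorophenyl on a carbonyl carbon. For the measured compounds named here, the one measured step that resembles this, a 1.1-fold lower number from compound 1 to compound 2 (0.05 log units; within the scatter), stayed within the scatter, so no step beyond the scatter is expected here either; the expected step is a 1.2-fold lower number from compound 3 to compound 4 (0.07 log units; within the scatter). Compound 4 is therefore estimated at 12500 nM in this assay, with a range from 6000 nM to 26000 nM.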

Compound 4, half-maximal inhibitory concentration: 16300 nM
Compound 4: the middle estimate sits 1.3-fold (0.12 log units) below what was measured; low and high end bracket the measured number.
By their numbers in this assay, from the lowest: compounds 2, 1, 3 and 4 (each within the scatter of the next).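

Replacing 4-chlorophenyl with cyclohexyl on this carbonyl carbon gives a 1.1-fold higher number from compound 3 to compound 4 (0.05 log units; within the scatter), so the ring swap now stays within the scatter on the core of compound 3 as well as on the core of compound 1. Losing the chlorine together with the aromatic ring therefore leaves no readable mark on the number here, and no available measurement offers a cause for this flat result. As far as these compounds go, all four compounds carry a six-membered carbon ring at this place, so it remains open whether a straight hexyl chain or a ring bearing an amine would move the number beyond the scatter.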